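This account rests on a few compounds, and the source may have more. Where it says the series, first, only, none or still open, it means among the compounds named here.

For the measured compounds named here, compound 1 `COc1cccc(NC2=CC(=O)c3c(nc4n3[C@H]3OC[C@@H](O)[C@H]3OC4)C2=O)c1` is the only member of this small set that returns a number: in a functional assay on ECa-109 cells for inhibition, with ECa-109 cell line (Homo sapiens) as the target, read by sulforhodamine B assay (a lower number here means a stronger inhibitor, a higher number a weaker inhibitor), compound 1 gives 3340 nM. Compound 2 `O=C1C=C(NCc2ccccc2)C(=O)c2c1nc1n2[C@H]2OC[C@@H](O)[C@H]2OC1` reaches only a limit, giving > 8000 nM in this assay. Compound 3 `COc1ccc(NC2=CC(=O)c3nc4n(c3C2=O)[C@H]2OC[C@@H](O)[C@H]2OC4)cc1` likewise reaches only a limit, giving > 4000 nM in this assay. The step that the two limits leave unreadable from compound 2 to compound 3 therefore cannot be read. Compound 4 `O=C1C(Nc2cccc(F)c2)=CC(=O)c2c1nc1n2[C@H]2OC[C@@H](O)[C@H]2OC1` differs from compound 1 by fluoro in place of methoxy on an aromatic carbon. Going by the values given here, no measured step touches this change, and the single measured step is unreadable, so nothing here points to a shift in either direction. Because compound 1 gives 3340 nM, compound 4 is expected to give about 3500 nM in this assay, within a range from 1500 nM to 8000 nM. The expected step of a 1.0-fold higher number from compound 1 to compound 4 (0.02 log units; within the scatter) is thus not beyond the scatter.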

Compound 4, half-maximal inhibitory concentration: 2370 nM
The estimate for compound 4 lay 1.5-fold (0.17 log units) above the measured number, within the range that was stated.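

In this assay, for the compounds shown here, the change from 3-methoxyphenyl to 3-fluorophenyl gives the first readable step: a 1.4-fold lower number from compound 1 to compound 4 (0.15 log units; within the scatter) and no more. This place on the aromatic ring, meta to a large group, therefore accepts fluoro in place of methoxy without a change beyond the scatter, and compound 4, like compound 1, returns a number and not a limit. On these data alone, whether a carboxylic acid, an amine or a longer chain at this place would move the number beyond the scatter remains open. Nothing shown here bears on why these two groups read alike.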